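Series notes: from compound 2 to compound 3 in cytotoxicity

The source may report more compounds than this note shows. Statements on the series, on what has been measured and on what is new or still open speak of the compounds shown alone.

Measured so far: compound 1 `O=C(Nc1ccc(Sc2nc3ccccc3s2)cc1)c1cc(Br)cc(Br)c1O` and compound 2 `COc1ccc(S(=O)(=O)Nc2ccc3oc(-c4ccc(NC(=O)c5ccc(Cl)s5)cc4)nc3c2)cc1`. In an ADME assay on HEK293 cells (Homo sapiens) for cytotoxicity, read by resazurin assay, with a stated time of 48 h (on this read-out lower numbers stand for higher toxicity in this test and higher numbers for lower toxicity in this test), compound 1 gives 69000 nM. In this assay compound 2 gives 15000 nM, the lowest of the two numbers, with compound 1 beyond the scatter above it. Compound 3 `COc1ccc(S(=O)(=O)Nc2ccc(-c3nc4cc(NS(=O)(=O)c5ccc(OC)cc5)ccc4o3)cc2)cc1` is not yet measured and differs from compound 2 in one place: (4-methoxyphenyl)sulfonyl in place of (5-chlorothiophen-2-yl)carbonyl on a nitrogen on an aromatic ring. Going by the values given here, no measured pair shares this change, so its step size is unknown. In this assay the step is expected to be small, if anything toward a higher number, possibly none beyond the scatter: a 1.7-fold higher number from compound 2 to compound 3 (0.22 log units; within the scatter). Compound 3 is estimated at 25000 nM, with a range from 8000 nM to 80000 nM.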

Compound 3, half-maximal cytotoxic concentration: 48000 nM
Compound 3: middle estimate off by 1.9-fold (0.28 log units), on the low side, and the stated range covers the measured number.
By their numbers in this assay, from the lowest: compound 2; then compounds 3 and 1 (each within the scatter of the next).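

In this assay, going by these compounds alone, the first one-place comparison gives a 3.2-fold higher number from compound 2 to compound 3 (0.51 log units; beyond the scatter) with (4-methoxyphenyl)sulfonyl in place of (5-chlorothiophen-2-yl)carbonyl. The group on this nitrogen therefore moves the number beyond the scatter, here toward lower toxicity in this test. Nothing available explains the step.

The change swaps the ring and the carbonyl-to-sulfonyl link together, so their separate contributions remain unresolved. Also open, as far as these compounds go, is how a (4-methoxyphenyl)carbonyl group, a (5-chlorothiophen-2-yl)sulfonyl group or a free amine at this position would read.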